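This account rests on a few compounds, and the source may have more. Where it says the series, first, only, none or still open, it means among the compounds named here.

Compound 1 `COc1ccc(C(=O)Nc2cccc(-c3oc4cc(-c5ccc(F)cc5)ccc4c(=O)c3O)c2)cc1` in a functional assay on HeLa cells (Homo sapiens) for antiproliferative activity, read by CCK-8 assay, with a stated time of 72 h (a lower number here means a stronger inhibitor, a higher number a weaker inhibitor), gives 4820 nM. Compound 2 `Cc1ccccc1C(=O)Nc1cccc(-c2oc3cc(-c4ccc(F)cc4)ccc3c(=O)c2O)c1` gives 11900 nM. Compound 3 `COc1cccc(C(=O)Nc2cccc(-c3oc4cc(-c5ccc(F)cc5)ccc4c(=O)c3O)c2)c1` gives 5650 nM.

Compound 3 stands close to compound 1 on these numbers, with a 1.2-fold higher number from compound 1 to compound 3 (0.07 log units; within the scatter), while the step of a 2.1-fold lower number from compound 2 to compound 3 (0.32 log units; beyond the scatter) sets it apart from compound 2. Compound 4 `O=C(Nc1cccc(-c2oc3cc(-c4ccc(F)cc4)ccc3c(=O)c2O)c1)c1cccc(F)c1` differs from compound 3 by fluoro in place of methoxy on an aromatic carbon, on an aromatic carbon of a six-membered aromatic ring of carbon only, meta to a large group. For the measured compounds named here, no measured step swaps methoxy for fluoro; the steps of a 2.5-fold higher number from compound 1 to compound 2 (0.39 log units; beyond the scatter) and a 2.1-fold lower number from compound 2 to compound 3 (0.32 log units; beyond the scatter) only show that changes on this aryl group shift this assay modestly. Compound 4 is therefore expected to give 6000 nM (range 2500 nM to 14000 nM), an estimated step of a 1.1-fold higher number from compound 3 to compound 4 (0.03 log units; within the scatter).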

Compound 4, half-maximal inhibitory concentration: 8780 nM
Beside the measured number, compound 4's estimate is 1.5-fold (0.17 log units) below it; measured number inside the range.
By their numbers in this assay, from the lowest: compounds 1, 3, 4 and 2 (each within the scatter of the next, the first and the last beyond it).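

In this assay, the swap of methoxy for fluoro on this aromatic carbon, meta to a large group, is now read directly, and a 1.6-fold higher number from compound 3 to compound 4 (0.19 log units; within the scatter) does not separate the two groups. Compound 4 is also not separated from the other two compounds, with a 1.4-fold lower number from compound 2 to compound 4 (0.13 log units; within the scatter) and a 1.8-fold higher number from compound 1 to compound 4 (0.26 log units; within the scatter), even though compound 1 and compound 2 differ from each other beyond the scatter. Nothing measured here offers a cause for this result.

Going by these compounds, whether an amine or a carboxylic acid at this place would move the number beyond the scatter remains open.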